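This account rests on a few compounds, and the source may have more. Where it says the series, first, only, none or still open, it means among the compounds named here.

Measured compounds:
Compound 1, `O=[N+]([O-])c1cccc(/C=N\NC(=S)NC2CCCCC2)c1`: 84800 nM
Compound 2, `S=C(N/N=C\c1ccc(Cl)cc1)NC1CCCCC1`: 38300 nM

Of these two, compound 2 has the lower number in a functional assay on MDA-MB-231 cells (Homo sapiens) for inhibition, read by WST assay, with a stated time of 48 h (on this read-out lower numbers stand for stronger inhibition and higher numbers for weaker inhibition), and the number for compound 1 is higher by more than the usual scatter. Compound 3, `CN(C)c1ccc(/C=N\NC(=S)NC2CCCCC2)cc1`, has not yet been measured. It differs from compound 2 in one place: dimethylamino in place of chloro on an aromatic carbon. Among the measured compounds shown here, no measured pair shows this exchange, so its effect cannot be read from the data. A modest shift in either direction, or none beyond the scatter, is expected in this assay. Compound 3 is therefore estimated at about 30000 nM, between 8000 nM and 120000 nM. The expected step is a 1.3-fold lower number from compound 2 to compound 3 (0.11 log units; within the scatter).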

Compound 3, half-maximal inhibitory concentration: 125000 nM
Beside the measured number, compound 3's estimate is 4.2-fold (0.62 log units) below it; the measured number lies above the stated range.
By their numbers in this assay, from the lowest: compound 2; then compounds 1 and 3 (each within the scatter of the next).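

In this assay, placing dimethylamino instead of chloro on this aromatic carbon, para to a large group, gives a 3.3-fold higher number from compound 2 to compound 3 (0.51 log units; beyond the scatter) and therefore weaker inhibition. This shows that the position is sensitive to the group it carries, at least for this one exchange. The data shown do not explain the change.

On these data alone, it remains open whether a simple amine or a carboxylic acid at this position would behave more like chloro or more like dimethylamino.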